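A few compounds are considered here, and "the series" means these few. Any claim that something is new, unique, unknown or untested is made for them only; others in the source may bear on it.

Measured compounds:
- compound 1, `O=C(Nc1ccc(Oc2ccnc3[nH]ccc23)cc1)c1nccc(-c2cccc(Cl)c2)n1`: 4120 nM
- compound 2, `O=C(Nc1ccc(Oc2ccnc3[nH]ccc23)cc1)c1nccc(-c2ccc(F)cc2)n1`: "not active" (no number reported)

Going by the values given here, in a functional assay on A549 cells (Homo sapiens) for cytotoxicity, read by MTT assay, with a stated time of 72 h (on this read-out higher numbers stand for weaker inhibition and lower numbers for stronger inhibition), compound 1 gives 4120 nM, the only number reported; compound 2 gives "not active" (no number reported) without a number. Compound 3, `O=C(Nc1ccc(Oc2ccnc3[nH]ccc23)c(F)c1)c1nccc(-c2cccc(Cl)c2)n1`, differs from compound 1 by fluoro in place of hydrogen on an aromatic carbon, a fluoro in place of hydrogen on an aromatic carbon. Among the compounds with values here, no measured pair isolates this change, so compound 1 is the sole anchor. With one small atom added, no step beyond the scatter is expected, and the estimated step of a 1.0-fold lower number from compound 1 to compound 3 (0.01 log units; within the scatter) stays within it. Compound 3 is expected to give 4000 nM, within 1500 nM to 11000 nM.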

Compound 3, half-maximal inhibitory concentration: 450 nM
Compound 3: middle estimate off by 8.9-fold (0.95 log units), on the high side; the whole stated range lies above it.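

In this assay, one fluoro in place of hydrogen on an aromatic carbon, ortho to a large group and meta to a large group, gives a 9.2-fold lower number from compound 1 to compound 3 (0.96 log units; beyond the scatter). This position on the core of compound 1 is therefore sensitive to change: a single added atom moves the number beyond the scatter. Nothing given here explains the step.

A chloro or a methoxy at this position could show whether the step is specific to fluoro. On these data alone, whether the same fluoro would lift compound 2, reported as not active, to a measurable number remains open.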